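The compounds below may be only part of what the source reports. "The series", "measured", "known", "first", "only" and "open" are said of these compounds alone.

Of the compounds shown here, two have been measured. Compound 1 `COc1cc(/C=N/Nc2nc(-c3ccc(F)c(F)c3)cs2)c(Br)c(Br)c1OC` carries a 3,4-difluorophenyl group on the shared core, and in a functional assay on A549 cells (Homo sapiens) for inhibition, read by MTT assay, with a stated time of 48 h (a lower number here means a stronger inhibitor, a higher number a weaker inhibitor), compound 1 gives 8380 nM. Within the data shown here, compound 2 `COc1ccccc1-c1csc(N/N=C/c2cc(OC)c(OC)c(Br)c2Br)n1` carries a 2-methoxyphenyl group in its place, and in this assay compound 2 gives 85100 nM, the highest of the two numbers so far; the change from compound 1 to compound 2 brought a 10-fold higher number from compound 1 to compound 2 (1.01 log units; beyond the scatter). The next compound, compound 3 `COc1cc(/C=N/Nc2nc(-c3cccc(Br)c3)cs2)c(Br)c(Br)c1OC`, differs from compound 2 in one place: 3-bromophenyl in place of 2-methoxyphenyl on an aromatic carbon. Among the measured compounds shown here, this step has no direct precedent, but compound 2 stands far above compound 1 because of a 10-fold higher number from compound 1 to compound 2 (1.01 log units; beyond the scatter), and compound 3 returns to a halogen-bearing ring and gives up the only acceptor of the leaving group, so a number between the two is expected, which means a step of about a 5.7-fold lower number from compound 2 to compound 3 (0.75 log units; beyond the scatter). Compound 3 in this assay is therefore estimated at 15000 nM, within a range from 4000 nM to 60000 nM.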

Compound 3, half-maximal inhibitory concentration: 37000 nM
Beside the measured number, compound 3's estimate is 2.5-fold (0.39 log units) below it; the range from low to high includes it.
By their numbers in this assay, from the lowest: compound 1; then compound 3; then compound 2.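

This position on the shared core responds to more than one kind of change: in this assay the swap to 3-bromophenyl gives a 2.3-fold lower number from compound 2 to compound 3 (0.36 log units; beyond the scatter), so removing the 2-methoxyphenyl group recovers only part of the earlier loss. A bromine-bearing ring does not match the difluorinated one, with a 4.4-fold higher number from compound 1 to compound 3 (0.64 log units; beyond the scatter), so the two halogen-bearing rings are clearly separated from each other, and both give lower numbers than the 2-methoxyphenyl ring. Nothing available explains why these three rings differ.

The compounds shown do not separate the kind of halogen from its place on the ring, as 3-bromophenyl and 3,4-difluorophenyl differ in both. Going by these compounds, how an unsubstituted phenyl, a 4-bromophenyl or a ring carrying an amine or a carboxylic acid would compare also remains open.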